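The source may report more compounds than this note shows. Statements on the series, on what has been measured and on what is new or still open speak of the compounds shown alone.

Working notes on the series built around compound 1 `CC(C)CN1C(=O)/C(=C/c2ccc(O)cc2)S/C1=N\c1ccccc1`. In an ADME assay on HepG2 cells (Homo sapiens) for cytotoxicity, read by MTT assay, with a stated time of 48 h (a lower number here means a stronger inhibitor, a higher number a weaker inhibitor), compound 1 stands at "not determined" (no result reported), so no number anchors it. Compound 2 `CC(C)CN1C(=O)/C(=C/c2ccccn2)S/C1=N\c1ccccc1` differs from compound 1 in the aromatic group on the exocyclic double bond. In this assay compound 2 returns only a limit, > 100000 nM, and not a number. The one result at hand thus sits at the limit of > 100000 nM in this assay, at which 1 of the 2 values shown sits. Compound 3 `COc1cc(/C=C2\S/C(=N\c3ccccc3)N(CC(C)C)C2=O)ccc1O` carries the change methoxy in place of hydrogen on an aromatic carbon relative to compound 1. Among the compounds with values here, no measured step joins compound 1 to compound 3, and none joins compound 1 to compound 2, so the size of this change has no measured precedent here. Expected in this assay is no shift beyond the scatter, in either direction, and most likely another limit rather than a number, because the limit of > 100000 nM in this assay, at which 1 of the 2 values shown sits, is the only reading the series gives. For compound 3 the estimated value is 100000 nM, with a range from 30000 nM to 300000 nM.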

Compound 3, half-maximal inhibitory concentration: 89500 nM
Estimate against measurement, compound 3: 1.1-fold (0.05 log units) above, within the range that was stated.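

In this assay, within the data shown here, compound 3 gives 89500 nM, the only true number so far, so the 4-hydroxy-3-methoxyphenyl group gives a reading that can be placed on the scale. Compound 2 remains a limit and not a number: the limit of > 100000 nM in this assay, at which 1 of the 3 values shown sits.

Going by these compounds, the change to 4-hydroxy-3-methoxyphenyl in place of pyridin-2-yl gives an at least 1.1-fold lower number from compound 2 to compound 3 (0.04 log units; that floor lies within the scatter), which is a floor only, so the real size of this step remains unknown.

On these data alone, the steps that touch compound 1 cannot be read, so the size of the change to methoxy in place of hydrogen on the 4-hydroxyphenyl group stays open. Also open, as far as these compounds go, is whether an ethoxy group or an amine on that same aromatic carbon would shift the value beyond the scatter.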